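Methyl to 4-bromobenzyl on a brominated compound

This account rests on a few compounds, and the source may have more. Where it says the series, first, only, none or still open, it means among the compounds named here.

Compound 1 `CN1C(=O)C(O)(Cc2nnn[nH]2)c2ccccc21`: 36800 nM
Compound 2 `CN1C(=O)C(O)(Cc2nnn[nH]2)c2cc(Br)ccc21`: > 100000 nM (a limit, not a number)

Compound 2 has no exact number in a functional assay on DU-145 cells (Homo sapiens) for antiproliferative activity, read by MTT assay, with a stated time of 48 h (a lower number here means a stronger inhibitor, a higher number a weaker inhibitor), only (the limit of > 100000 nM in this assay, at which 1 of the 2 values shown sits). Compound 3 `O=C1N(Cc2ccc(Br)cc2)c2ccc(Br)cc2C1(O)Cc1nnn[nH]1` differs from it by 4-bromophenyl in place of hydrogen on a saturated chain carbon bound to an amide-type nitrogen in a ring, which turns methyl into 4-bromobenzyl. Within the data shown here, the only measured step, an at least 2.7-fold higher number from compound 1 to compound 2 (0.43 log units; beyond the scatter), put bromo on an aromatic carbon, a different place, so it offers weak guidance here. Compound 1 reaches 36800 nM, so a measurable number in that region seems possible. Compound 3 could also end up without an exact number. The expected change is a lower number, an at least 2.5-fold lower number from compound 2 to compound 3 (0.39 log units; beyond the scatter). For compound 3 the estimated value is 40000 nM, with an expected range of 8000 nM to 100000 nM.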

Compound 3, half-maximal inhibitory concentration: 59600 nM
Compound 3: middle estimate off by 1.5-fold (0.17 log units), on the low side; measured number inside the range.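

In this assay, replacing methyl with 4-bromobenzyl on the amide-type nitrogen in the ring gives an at least 1.6-fold lower number from compound 2 to compound 3 (0.22 log units; that floor lies within the scatter). Compound 2 has only a limit, > 100000 nM, and not a number. This step therefore shows that the larger group still allows an exact reading on the brominated core, but it does not establish a real gain.

As far as these compounds go, it remains open whether plain benzyl or a longer chain ending in an amine would give a lower number here. From the compounds shown here alone, the effect of 4-bromobenzyl on the core of compound 1 is also open.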